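The source may hold more compounds than are shown below. What is called first, only, known or untested is meant among the compounds shown, and "the series" means these compounds.

Working notes on the series. In a functional assay on HCT-116 cells (Homo sapiens) for cytotoxicity, read by MTT assay, with a stated time of 72 h (a higher number here means a weaker inhibitor, a lower number a stronger inhibitor), compound 1 (`C[C@@H](Nc1c(C(=O)NCc2ccc(F)cc2)nc(Br)c2cccnc12)c1ccccc1`) gives > 20000 nM, which is a limit. Compound 2 (`CN(C)CCCNc1c(C(=O)NCc2ccc(F)cc2)nc(Br)c2cccnc12`) gives > 10000 nM, also a limit, so its position is known only as a limit.

Compound 3 (`O=C(NCCCNc1c(C(=O)NCc2ccc(F)cc2)nc(Br)c2cccnc12)c1ccccc1`) differs from compound 2 by benzamido in place of dimethylamino on a saturated chain carbon, three bonds along the chain from a nitrogen on an aromatic ring.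

For the measured compounds named here, the only measured step that bears on this change is a step that the two limits leave unreadable from compound 1 to compound 2. It provides no size to carry forward, and no direction is supported. No step beyond the scatter is expected in this assay, an expectation resting on compound 2 and its limit of > 10000 nM. The estimated step is a step that the limit leaves unreadable from compound 2 to compound 3. For compound 3, the expected value is 15000 nM, with an estimated range of 4000 nM to 40000 nM.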

Compound 3, half-maximal inhibitory concentration: > 10000 nM
Compound 3: only a limit was reported (the forecaster's own chance of this, stated with the estimate: 60%); the middle value is on the limit's open side.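

In this assay, compound 2 and compound 3 are each reported only as a limit, so no step can be read between them. The compounds shown leave open whether benzamido in place of dimethylamino changes potency at all, since none has a value that is a number.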